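This account rests on a few compounds, and the source may have more. Where it says the series, first, only, none or still open, it means among the compounds named here.

Compound 1 `Fc1ccc(OC[C@@H]2CCN2)cn1` gives 0.057 nM in an assay on brain for binding affinity to Neuronal acetylcholine receptor; alpha4/beta2 (Rattus norvegicus), read by radioligand binding; a higher number here means a weaker inhibitor, a lower number a stronger inhibitor.
Compound 2 `CCc1ccc(OC[C@@H]2CCN2)cn1` gives 19 nM in this assay.
Compound 3 `N#Cc1ccc(OC[C@@H]2CCN2)cn1` gives 1.9 nM in this assay.

Compound 2 has the highest number of the three, with the others below it, as seen in a 330-fold higher number from compound 1 to compound 2 (2.52 log units; beyond the scatter) and a 10-fold lower number from compound 2 to compound 3 (1.00 log units; beyond the scatter).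

Compound 4 `C=Cc1ccc(OC[C@@H]2CCN2)cn1` differs from compound 2 in one place: vinyl in place of ethyl on an aromatic carbon.

Within the data shown here, no measured step replaces ethyl with vinyl. Among the measured compounds shown here, the steps that bear on it are those at the same aromatic carbon: a 10-fold lower number from compound 2 to compound 3 (1.00 log units; beyond the scatter), a modest move, and a 330-fold higher number from compound 1 to compound 2 (2.52 log units; beyond the scatter), a large one. Because a 33-fold higher number from compound 1 to compound 3 (1.52 log units; beyond the scatter) and every other change tried at this carbon shifted this assay beyond the scatter, a modest downward shift is expected for compound 4, roughly a 3.8-fold lower number from compound 2 to compound 4 (0.58 log units; beyond the scatter). Compound 4 is therefore estimated at 5 nM, within 1.5 nM to 20 nM.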

Compound 4, inhibition constant: 1.25 nM
Beside the measured number, compound 4's estimate is 4.0-fold (0.60 log units) above it; the measured number lies below the stated range.
By their numbers in this assay, from the lowest: compound 1; then compounds 4 and 3 (each within the scatter of the next); then compound 2.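

Swapping ethyl for vinyl keeps the same number of heavy atoms and adds only one double bond, yet it gives a 15-fold lower number from compound 2 to compound 4 (1.18 log units; beyond the scatter) in this assay, so this aromatic carbon responds to even so small a change. Vinyl and cyano cannot be told apart, with a 1.5-fold lower number from compound 3 to compound 4 (0.18 log units; within the scatter) as the step between them, while fluoro stays clearly better, as a 22-fold higher number from compound 1 to compound 4 (1.34 log units; beyond the scatter) shows. Nothing available explains why the double bond matters here.

Still open, going by these compounds, is whether ethynyl or a longer chain such as propyl would keep this gain. On these data alone, whether an amine or chloro at this carbon would come closer to fluoro is also open.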